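The compounds below may be only part of what the source reports. "The series", "measured", "known", "first", "only" and "open" are said of these compounds alone.

In a functional assay on A549 cells (Homo sapiens) for cytotoxicity, read by MTT assay, with a stated time of 48 h (on this read-out lower numbers stand for stronger inhibition and higher numbers for weaker inhibition), compound 1 `COc1ccc(C2=NOC(COc3ccc(-c4nnnn4-c4cc(OC)c(OC)c(OC)c4)cc3N)C2)cc1N` gives 2080 nM and compound 2 `COc1cc(C2=NOC(COc3ccc(-c4nnnn4-c4cc(OC)c(OC)c(OC)c4)cc3N)C2)ccc1O` gives 2010 nM. For the measured compounds named here, these two numbers lie within the scatter of each other, so compound 2 stands level with the only other measured compound. Compound 3 `COc1cc(-n2nnnc2-c2ccc(OCC3CC(c4ccc(C(F)(F)F)cc4)=NO3)c(N)c2)cc(OC)c1OC` differs from compound 2 at one place: 4-(trifluoromethyl)phenyl in place of 4-hydroxy-3-methoxyphenyl on a carbon with a double bond to nitrogen. In short, 4-(trifluoromethyl)phenyl stands in place of 4-hydroxy-3-methoxyphenyl on the same carbon with a double bond to nitrogen. Going by the values given here, only one measured step bears on this change, and it concerns that same carbon: a 1.0-fold lower number from compound 1 to compound 2 (0.01 log units; within the scatter). There, 4-hydroxy-3-methoxyphenyl took the place of 3-amino-4-methoxyphenyl and the number stayed within the scatter. This single step gives no reason to expect a clear shift in this assay, but it is thin evidence, since no measured compound carries the 4-(trifluoromethyl)phenyl group. The expected change is a 1.2-fold higher number from compound 2 to compound 3 (0.09 log units; within the scatter), which would remain within the scatter, with no firm direction. For compound 3 the estimated value is 2500 nM, with an expected range from 800 nM to 8000 nM.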

Compound 3, half-maximal inhibitory concentration: 1220 nM
Estimate against measurement, compound 3: 2.0-fold (0.31 log units) above; low and high end bracket the measured number.
By their numbers in this assay, from the lowest: compounds 3, 2 and 1 (each within the scatter of the next).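

In this assay, the change to 4-(trifluoromethyl)phenyl shows a 1.6-fold lower number from compound 2 to compound 3 (0.22 log units; within the scatter) when it replaces 4-hydroxy-3-methoxyphenyl and a 1.7-fold lower number from compound 1 to compound 3 (0.23 log units; within the scatter) when it replaces 3-amino-4-methoxyphenyl on the same carbon with a double bond to nitrogen. The earlier pair compared only two substituted phenyl groups that both carried a methoxy group, whereas here the entering group has neither hydrogen-bond donors nor hydrogen-bond acceptors and the leaving 4-hydroxy-3-methoxyphenyl has both, yet the step stays within the scatter, so among these three compounds the exchange of groups at this position gives no separation in this read-out. No supporting measurement is available that could account for this outcome.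

All three groups at this position are substituted phenyl rings, so the compounds shown do not tell whether a clear shift appears with a different kind of group there, such as a pyridine ring, a carboxylic acid, an amine or a longer alkyl chain. They also leave open whether the same exchanges would stay within the scatter on another cell line or with changes elsewhere in the shared core.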